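This account rests on a few compounds, and the source may have more. Where it says the series, first, only, none or still open, it means among the compounds named here.

Measured compounds:
Compound 1 `COc1ccc2[nH]c(C(=O)N3CC(=O)N(Cc4ccccc4)[C@@H](COCc4ccccc4)C3)cc2c1` gives > 30000 nM in an ADME assay on Vero cells (Chlorocebus sabaeus) for cytotoxicity, with a stated time of 7 days; a higher number here means that more compound is tolerated, a lower number that less compound is tolerated; this is a limit of the assay, not a number.
Compound 2 `COc1ccc2[nH]c(C(=O)N3CC(=O)N(Cc4ccccc4)[C@@H](CN4CCN(c5ccccn5)CC4)C3)cc2c1` gives > 30000 nM in this assay; this too is a limit, not a number.

Compound 2 therefore stands only at a limit, with no measured number behind it. Both values sit at the limit of > 30000 nM in this assay, at which 2 of the 2 values shown sit, so the step that the two limits leave unreadable from compound 1 to compound 2 cannot be read in either size or direction.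

Compound 3 `COc1ccc2[nH]c(C(=O)N3CC(=O)N(Cc4ccccc4)[C@@H](CN4CCc5ccccc5C4)C3)cc2c1` differs from compound 2 by 1,2,3,4-tetrahydroisoquinolin-2-yl in place of 4-(pyridin-2-yl)piperazin-1-yl on a saturated chain carbon bound to a saturated ring carbon. No measured step bears on a change of this kind; the single step shown is itself unreadable. With both measured compounds tolerated up to the limit, the expectation for compound 3 is no step beyond the scatter, a step that the limit leaves unreadable from compound 2 to compound 3, and that the assay again reports only a limit. For compound 3 the estimated value in this assay is 35000 nM, expected between 15000 nM and 80000 nM.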

Compound 3, half-maximal cytotoxic concentration: 51800 nM
The estimate for compound 3 lay 1.5-fold (0.17 log units) below the measured number, within the range that was stated.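

The steps from compound 1 and from compound 2 to compound 3 cannot be read, since compound 1 and compound 2 stand only at a limit, not a number: the limit of > 30000 nM in this assay, at which 2 of the 3 values shown sit.

Going by these compounds, whether 1,2,3,4-tetrahydroisoquinolin-2-yl changes how much compound the cells tolerate, relative to benzyloxy or 4-(pyridin-2-yl)piperazin-1-yl, remains open in both size and direction.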